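This account rests on a few compounds, and the source may have more. Where it says the series, first, only, none or still open, it means among the compounds named here.

Working notes on the series. The three measured compounds share one core and differ only in the group carried on one aromatic carbon. In a functional assay on CHO-K1 cells for antagonist activity at adenosine receptor A1 (Homo sapiens), read by a beta-galactosidase reporter and cAMP accumulation, with stated times of 15 min and 6 h (a higher number here means a weaker inhibitor, a lower number a stronger inhibitor), compound 1 `Nc1nc(-c2ccc(C(F)F)o2)nc2sc(Cc3ccccc3)cc12` gives 3000 nM, compound 2 `Cc1nc(-c2nc(N)c3cc(Cc4ccccc4)sc3n2)cs1` gives 263 nM, and compound 3 `Nc1nc(-c2cccc(F)c2)nc2sc(Cc3ccccc3)cc12` gives 123 nM. Compound 3 stands lowest of the three: there is a 2.1-fold lower number from compound 2 to compound 3 (0.33 log units; beyond the scatter), and there is a 24-fold lower number from compound 1 to compound 3 (1.39 log units; beyond the scatter). The remaining step is an 11-fold lower number from compound 1 to compound 2 (1.06 log units; beyond the scatter).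

The next compound, compound 4 `N#Cc1cncc(-c2nc(N)c3cc(Cc4ccccc4)sc3n2)c1`, differs from compound 3 in this way: 5-cyanopyridin-3-yl in place of 3-fluorophenyl on an aromatic carbon. For the measured compounds named here, the steps that bear on it are the two in which the group on this carbon was exchanged against the 3-fluorophenyl of compound 3. Read away from compound 3, both went to higher numbers, one modest and one large, as shown by a 2.1-fold lower number from compound 2 to compound 3 (0.33 log units; beyond the scatter) and a 24-fold lower number from compound 1 to compound 3 (1.39 log units; beyond the scatter). Neither earlier exchange brought in a six-membered aromatic ring with a hetero atom or a triple bond outside aromatic rings, so the size can only be taken from the general tendency of the two exchanges. A modest rise in this assay is expected, so the expected step for compound 4 is a 2.4-fold higher number from compound 3 to compound 4 (0.39 log units; beyond the scatter). The estimate for compound 4 in this assay is 300 nM, with an expected range from 100 nM to 1000 nM.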

Compound 4, inhibition constant: 1160 nM
Beside the measured number, compound 4's estimate is 3.9-fold (0.59 log units) below it; the whole stated range lies below it.
By their numbers in this assay, from the lowest: compound 3; then compound 2; then compound 4; then compound 1.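

In this assay, a 9.4-fold higher number from compound 3 to compound 4 (0.97 log units; beyond the scatter) shows that a six-membered aromatic ring on this carbon does not by itself keep the number low: 5-cyanopyridin-3-yl, with its ring hetero atom and a triple bond outside aromatic rings, stands well apart from 3-fluorophenyl. The new group also gives a higher number than 2-methyl-1,3-thiazol-4-yl, with a 4.4-fold higher number from compound 2 to compound 4 (0.64 log units; beyond the scatter), but a lower one than 5-(difluoromethyl)furan-2-yl, with a 2.6-fold lower number from compound 1 to compound 4 (0.41 log units; beyond the scatter), so the two six-membered groups do not sort together at this position, and compound 4 falls within the range set by the other two groups. No measurement shown here accounts for these steps.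

The ring nitrogen and the nitrile enter together in compound 4, so their separate shares of the change stay unresolved; pyridin-3-yl and 3-cyanophenyl would each carry only one of the two. A plain phenyl on this carbon would likewise show how much of the number of compound 3 depends on its fluorine.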